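The source may report more compounds than this note shows. Statements on the series, on what has been measured and on what is new or still open speak of the compounds shown alone.

Measured so far:
compound 1 `Cc1ccccc1CN1CCc2c(sc(NC(=O)c3ccccc3Cl)c2C(N)=O)C1` — > 50000 nM
compound 2 `NC(=O)c1c(NC(=O)c2ccccc2Cl)sc2c1CCN(Cc1ccc([N+](=O)[O-])cc1)C2` — 31500 nM

In a functional assay on MKN-74 cells (Homo sapiens) for antiproliferative activity, with a stated time of 24 h (on this read-out higher numbers stand for weaker inhibition and lower numbers for stronger inhibition), compound 1 reaches only a limit, > 50000 nM. Compound 2 gives 31500 nM in this assay; this is the only number shown, so compound 2 stands alone as a measured point. Within the data shown here, the single measured step, an at least 1.5-fold lower number from compound 1 to compound 2 (0.20 log units; that floor lies within the scatter), rests on the limit of > 50000 nM in this assay, at which 1 of the 2 values shown sits, and is therefore of unknown size beyond its floor.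

Compound 3 `NC(=O)c1c(NC(=O)c2ccccc2Cl)sc2c1CCN(C(=S)Nc1ccccc1F)C2` differs from compound 2 by a group of 10 heavy atoms (7 carbon, 1 nitrogen, 1 fluorine, 1 sulfur; one six-membered aromatic ring of carbon only) in place of a group of 10 heavy atoms (7 carbon, 1 nitrogen, 2 oxygen; one six-membered aromatic ring of carbon only), on an amine nitrogen in a ring. Among the measured compounds shown here, the one measured step also alters the group on this ring nitrogen, yet it only exchanges one aromatic ring for another within a benzyl group and reaches at most the scatter floor. For the measured compounds named here, the present change replaces the whole group, and no measured step covers it. No step beyond the scatter is expected; a wide range is kept. Compound 3 is estimated at 30000 nM (range 8000 nM to 100000 nM), an expected step of a 1.1-fold lower number from compound 2 to compound 3 (0.02 log units; within the scatter).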

Compound 3, half-maximal inhibitory concentration: 12600 nM
Beside the measured number, compound 3's estimate is 2.4-fold (0.38 log units) above it; low and high end bracket the measured number.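

Among these compounds, on this amine nitrogen in a ring, the group of compound 3 gives the first step beyond the scatter in this assay: a 2.5-fold lower number from compound 2 to compound 3 (0.40 log units; beyond the scatter), a modest one. Both groups hold 10 heavy atoms and one six-membered aromatic ring, so this step comes with no change in those counts, while the hydrogen-bond donors go from 0 to 1 and fluorine and sulfur enter together. The step of an at least 3.9-fold lower number from compound 1 to compound 3 (0.59 log units; beyond the scatter) gives only a floor, as compound 1 stands at a limit: the limit of > 50000 nM in this assay, at which 1 of the 3 values shown sits.

The compounds shown do not separate the part played by the sulfur, the fluorine and the added donor, and an oxygen in place of the sulfur or an unsubstituted phenyl ring would bear on this. Going by these compounds, the rest of the shared core stays constant throughout, so how a carboxylic acid or an amine in place of the primary amide would read in this assay remains open.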